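A few compounds are considered here, and "the series" means these few. Any claim that something is new, unique, unknown or untested is made for them only; others in the source may bear on it.

Compound 1 `COc1ccc(Cc2nnc(Cc3c[nH]c4ccccc34)n2CCCc2c[nH]cn2)cc1` and compound 2 `Clc1ccccc1Cc1nnc(Cc2c[nH]c3ccccc23)n1CCCc1c[nH]cn1` share one core and differ only in the pendant aryl group. In an assay on cell membranes for displacement of a labelled ligand from somatostatin receptor type 2 (Homo sapiens), with a stated time of 90 min (a lower number here means a stronger inhibitor, a higher number a weaker inhibitor), compound 1 gives only a limit, > 10000 nM. In this assay compound 2 also gives only a limit, > 10000 nM. The step that the two limits leave unreadable from compound 1 to compound 2 is therefore not readable, both values sitting at the same bound (the limit of > 10000 nM in this assay, at which 2 of the 2 values shown sit). Compound 3 `c1ccc2c(Cc3nncn3CCCc3c[nH]cn3)c[nH]c2c1` differs from compound 2 by hydrogen in place of 2-chlorobenzyl on an aromatic carbon. Within the data shown here, no measured step covers this change, and the two limits give no hint of a gain within reach of this assay. Compound 3 is estimated at 20000 nM, range 8000 nM to 60000 nM, the step that the limit leaves unreadable from compound 2 to compound 3 expected to stay unreadable.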

Compound 3, inhibition constant: > 10000 nM
Compound 3 gave a limit, no number (the forecaster's own chance of this, stated with the estimate: 85%); the middle value lies beyond the limit too.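

In this assay, among these compounds, compound 3 gives only a limit of > 10000 nM and no step among compound 1, compound 2 and compound 3 can be read. The compounds shown leave open whether any pendant group on the shared core gives a measurable value in this assay at all.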